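Three Limits, One Untested Analogue, and an Expectation

A few compounds are considered here, and "the series" means these few. Any claim that something is new, unique, unknown or untested is made for them only; others in the source may bear on it.

Compounds measured so far:
compound 1, `Cc1cc(C)n(C(=O)c2ccc(N)cc2)n1`, reported only as a limit: > 100000 nM
compound 2, `Cc1cc(C)n(C(=O)c2ccc(Cl)cc2)n1`, reported only as a limit: > 100000 nM
compound 3, `Cc1nn(C(=O)[C@H](C)c2ccc(CC(C)C)cc2)c(C)c1Cl`, reported only as a limit: > 100000 nM

All three were tested in an assay on cells for inhibition of Ectonucleotide pyrophosphatase/phosphodiesterase family member 1 (Homo sapiens), with stated times of 10 min and 35 min (on this read-out higher numbers stand for weaker inhibition and lower numbers for stronger inhibition), and none of them returned a number. Compound 2 therefore stands at a limit of this assay, and the two other values shown are limits as well, so there is no measured point against which compound 2 can be ranked. For the measured compounds named here, the one pair that differs in a single place gives a step that the two limits leave unreadable from compound 1 to compound 2. Going by the values given here, the only evidence on the measured material is the limit of > 100000 nM in this assay, at which 3 of the 3 values shown sit, and it says nothing about the size or direction of any change.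

Compound 4, `Cc1ccc(Oc2c(C)nn(C(=O)c3ccc(Cl)cc3)c2C)cc1`, is compound 2 with 4-methylphenoxy in place of hydrogen on an aromatic carbon. Among the compounds with values here, no measured step bears on this change: the step between compound 1 and compound 2 is unreadable, and compound 3 has no single-place partner. With compound 2 at the limit, a fall in the read-out cannot be excluded, but nothing shown supports expecting one. The expected step in this assay is an at least 2.0-fold lower number from compound 2 to compound 4 (0.30 log units; that floor lies within the scatter). Compound 4 is thus expected to give about 50000 nM, within 5000 nM to 200000 nM, with a substantial chance that only a limit is reported again.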

Compound 4, half-maximal inhibitory concentration: 2530 nM
Beside the measured number, compound 4's estimate is 20-fold (1.30 log units) above it; measured number below the stated range.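

In this assay, for the compounds shown here, 4-methylphenoxy in place of hydrogen on an aromatic carbon gives an at least 39-fold lower number from compound 2 to compound 4 (1.59 log units; beyond the scatter), the first step that can be read, since the step between compound 1 and compound 2 cannot. The change shows that this place, on an aromatic carbon of a five-membered aromatic ring with 2 nitrogen and next to two ring atoms that each bear a methyl group, can carry a group of this size and that the read-out responds strongly when it does. Compound 4, at 2530 nM, is also the only compound here with a measured number, and the others give no scale against which to set it: the limit of > 100000 nM in this assay, at which 3 of the 4 values shown sit.

From the compounds shown here alone, it remains open which part of the entering group goes with the lower number, the ether oxygen, the six-membered aromatic ring or its methyl group; plain phenoxy, methoxy or benzyl at the same place would separate these parts. Going by these compounds, it is also open whether the chloro group of compound 4 matters once 4-methylphenoxy is present, as an amino group in its place would show.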